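The source may hold more compounds than are shown below. What is called first, only, known or untested is meant among the compounds shown, and "the series" means these compounds.

Measured so far in a functional assay on BV-2 cells (Mus musculus) for inhibition, read by Griess assay, with stated times of 3 h and 24 h; a higher number here means a weaker inhibitor, a lower number a stronger inhibitor:
compound 1 `CC(C)(C)c1ccc(CS(=O)(=O)/C=C/c2ccc(O)c(O)c2)cc1` gives 12600 nM
compound 2 `[O-][S+](/C=C/c1ccc(O)c(O)c1)CCc1ccccc1` gives 42600 nM
compound 3 `[O-][S+](/C=C/c1ccc(O)c(O)c1)CCCc1ccccc1` gives 28600 nM

All three share the same catechol-bearing core and differ only in the group carried on the sulfur side. Among these three numbers compound 3 holds the second highest; its nearest neighbour is compound 2, and the distance between them lies within the scatter, while the gap to compound 1 lies beyond it.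

The next compound to be tested, compound 4 `[O-][S+](/C=C/c1ccc(O)c(O)c1)CCCCc1ccccc1`, grows the chain by one more unit: benzyl in place of phenyl on a saturated chain carbon, three bonds along the chain from a sulfur. One measured step speaks directly to this kind of change, the lengthening from compound 2 to compound 3, which gave a 1.5-fold lower number from compound 2 to compound 3 (0.17 log units; within the scatter). That step did not clear the scatter, so a single further lengthening of the same chain offers no firm ground for expecting a change of meaningful size in this assay in either direction. The expected step is therefore small, a 1.1-fold lower number from compound 3 to compound 4 (0.06 log units; within the scatter), and falls inside the usual scatter. On this basis compound 4 is estimated at 25000 nM, with a range from 10000 nM to 60000 nM.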

Compound 4, half-maximal inhibitory concentration: 36800 nM
Beside the measured number, compound 4's estimate is 1.5-fold (0.17 log units) below it, and the stated range covers the measured number.
By their numbers in this assay, from the lowest: compound 1; then compounds 3, 4 and 2 (each within the scatter of the next).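

In this assay, the second lengthening of the chain, a 1.3-fold higher number from compound 3 to compound 4 (0.11 log units; within the scatter), again stays inside the usual scatter, so this position now has two such steps rather than one. Set beside the earlier step, a 1.5-fold lower number from compound 2 to compound 3 (0.17 log units; within the scatter), it does not continue in the same direction, and compounds 2, 3 and 4 therefore show no trend with chain length and cannot be ranked against one another. No measurement here explains why swapping phenyl for benzyl at this place, three bonds along the chain from a sulfur, leaves the number within the scatter.

As far as these compounds go, it remains open whether a longer chain than that of compound 4, or an amine or a carboxylic acid in place of the phenyl at the chain end, would move the number beyond the scatter. Compound 1, at 12600 nM, differs from the others in more than one place, so the compounds shown do not tie its number to any single structural change.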